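Sulfonyl aryl change on a quinoline-type core

The source may hold more compounds than are shown below. What is called first, only, known or untested is meant among the compounds shown, and "the series" means these compounds.

Three compounds sharing one core have been examined in an assay on isolated protein for displacement of a labelled ligand from metabotropic glutamate receptor 5 (Homo sapiens), with a stated time of 60 min, tested at 1 uM; a lower number here means less inhibition, a higher number more inhibition at the concentration tested (going by the name of the read-out). Compound 1 `Cc1ccc(S(=O)(=O)c2cnc3ccc(Cl)cc3c2N2CCC(C)CC2)cc1` gives 95%, compound 2 `Cc1ccc(S(=O)(=O)c2cnc3ccc(Cl)cc3c2N2CCC(C)CC2)cc1F` gives 68%, and compound 3 `CC1CCN(c2c(S(=O)(=O)c3cc(F)cc(F)c3)cnc3ccc(Cl)cc23)CC1` gives 93%. Compound 3 thus stands second highest of the three, with compound 1 nearest and within the scatter, and compound 2 furthest, beyond it. Compound 4 `CC1CCN(c2c(S(=O)(=O)c3ccc(F)cc3)cnc3ccc(Cl)cc23)CC1` differs from compound 3 by 4-fluorophenyl in place of 3,5-difluorophenyl on a sulfonyl sulfur. Two earlier swaps on the sulfonyl sulfur bear on this: a number 2 percentage points lower from compound 1 to compound 3 (within the scatter) and a number 25 percentage points higher from compound 2 to compound 3 (beyond the scatter). One was flat, the other modest, so a small step is expected here. The step of a number 6 percentage points lower from compound 3 to compound 4 (within the scatter) is estimated to stay within or near the scatter. Compound 4 is expected to give 87%, between 68% and 97%.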

Compound 4, a percentage reported as inhibition, at one concentration (the size of the read-out at that concentration, not a potency): 89%
Compound 4: middle estimate off by 2 percentage points, on the low side, within the range that was stated.
By their numbers in this assay, from the lowest: compound 2; then compounds 4, 3 and 1 (each within the scatter of the next).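

With 4-fluorophenyl on the sulfonyl sulfur, the methyl of compound 1 proves dispensable in this assay: fluoro in its place gives a number 6 percentage points lower from compound 1 to compound 4 (within the scatter) and the step to the 3,5-difluorophenyl group is a number 4 percentage points lower from compound 3 to compound 4 (within the scatter) as well. Compound 2 goes against this flat picture, as the 3-fluoro-4-methylphenyl group stands apart with a number 21 percentage points higher from compound 2 to compound 4 (beyond the scatter) here too. No supporting data explain these steps. Open, from the compounds shown here alone, is how a methoxy group, a chlorine or an amine on this aryl ring would read.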